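Adding Chloro to a Weakly Cytotoxic Compound

This account rests on a few compounds, and the source may have more. Where it says the series, first, only, none or still open, it means among the compounds named here.

Compound 1 `O=C1/C(=C/c2coc3ccccc3c2=O)N=C(c2ccc(Cl)cc2)N1c1ccc(S(=O)(=O)Nc2ncccn2)cc1`: > 100000 nM
Compound 2 `O=C1/C(=C/c2coc3ccccc3c2=O)N=C(c2ccccc2)N1c1ccc(S(=O)(=O)Nc2nccs2)cc1`: 88500 nM

In a functional assay on MCF7 cells (Homo sapiens) for cytotoxicity, read by sulforhodamine B assay, with a stated time of 72 h (on this read-out lower numbers stand for stronger inhibition and higher numbers for weaker inhibition), compound 2 gives 88500 nM, the only numeric result available. For compound 1 the result is a limit of the assay, > 100000 nM. One of the two results sits at that limit (the limit of > 100000 nM in this assay, at which 1 of the 2 values shown sits). Compound 3 `O=C1/C(=C/c2coc3ccccc3c2=O)N=C(c2ccc(Cl)cc2)N1c1ccc(S(=O)(=O)Nc2nccs2)cc1` differs from compound 2 by chloro in place of hydrogen on an aromatic carbon. For the measured compounds named here, no measured step of this kind exists here, so the expected change a 1.1-fold higher number from compound 2 to compound 3 (0.03 log units; within the scatter) is none beyond the usual scatter. Compound 3 is estimated at 95000 nM, within 45000 nM to 200000 nM.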

Compound 3, half-maximal inhibitory concentration: > 100000 nM
Compound 3: no number, only a limit; the forecaster's own chance of this, stated with the estimate: 45%; at least 1.0-fold (0.02 log units) between middle value and limit.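

In this assay, chloro in place of hydrogen, para to a large group, gives an at least 1.1-fold higher number from compound 2 to compound 3 (0.05 log units; that floor lies within the scatter). As far as these compounds go, compound 3 gives > 100000 nM, which is a limit, so only that floor can be read and the true size of the step remains unknown. The step from compound 1 to compound 3 cannot be read, and most results now sit at the limit: the limit of > 100000 nM in this assay, at which 2 of the 3 values shown sit.

From the compounds shown here alone, it remains open whether a fluoro, a methoxy or an amine at this place would give a clearly lower number. Going by these compounds, the true values of compound 1 and compound 3 also remain unknown.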